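A few compounds are considered here, and "the series" means these few. Any claim that something is new, unique, unknown or untested is made for them only; others in the source may bear on it.

In an in vitro functional assay on HEK285-7 cells for antagonist activity at prostaglandin D2 receptor 2 (Homo sapiens), read by BRET and beta-arrestin recruitment (a lower number here means a stronger inhibitor, a higher number a weaker inhibitor), the three measured compounds fall at two extremes. Compound 1 `Nc1nc(-c2ccc(Cl)cc2)c(CC(=O)O)s1` returns only a limit, > 100000 nM. Compound 2 `O=C(O)Cc1sc(C(c2ccc(F)cc2)c2ccc(F)cc2)nc1-c1ccnc(N2CCC2)c1` likewise returns only a limit, > 100000 nM. Compound 3 `O=C(O)Cc1sc(C(c2ccccc2)c2ccc(Cl)cc2)nc1-c1ccc(Cl)cc1` differs from compound 2 on both sides of the shared core. In this assay compound 3 gives 75 nM and is the only one of the three with a measurable number. Compound 2 therefore sits at the limit of > 100000 nM in this assay, at which 2 of the 3 values shown sit, the weak end of what has been seen, alongside compound 1.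

Compound 4 `O=C(O)Cc1sc(C(c2ccc(F)cc2)c2ccc(F)cc2)nc1-c1cc(F)nc(F)c1` has not yet been measured. It differs from compound 2 in one place: 2,6-difluoropyridin-4-yl in place of 2-(azetidin-1-yl)pyridin-4-yl on an aromatic carbon. Among the compounds with values here, no pair of measured compounds differs in a single place, so the size of this kind of change cannot be read from a measured step. What can be said is that compound 3, with a different aromatic group at the same position of the core, reaches 75 nM. Compound 2, by contrast, returns only a limit.

The step from compound 2 to compound 4 is expected to be an at least 33-fold lower number from compound 2 to compound 4 (1.52 log units; beyond the scatter), a gain well beyond the scatter, though with a real chance that compound 4 also returns only a limit. Compound 4 is expected to give about 3000 nM, within a range from 200 nM to 50000 nM.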

Compound 4, half-maximal inhibitory concentration: 110 nM
Compound 4: middle estimate off by 27-fold (1.44 log units), on the high side, outside the stated range (below it).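

In this assay, within the data shown here, this exchange on the aromatic carbon gives the first measured step: an at least 900-fold lower number from compound 2 to compound 4 (2.95 log units; beyond the scatter). The step starts from a limit and not a number, so it gives only a lower bound on the size of the change: the limit of > 100000 nM in this assay, at which 2 of the 4 values shown sit.

With the large group and the carboxymethyl group held the same, the result shows that the group at this position alone can separate a limit from a measured value, something compound 2 and compound 3 could not show because they differ on both sides of the shared core.

The compounds shown leave open whether the gain comes from losing the azetidine ring or from gaining the two fluorine atoms, since the change does both at once and no compound here separates the two. Also open, from the compounds shown here alone, is how this assay would read a pyridin-4-yl group carrying a single fluorine, a chlorine or a methoxy group, or a dimethylamino group in place of the azetidin-1-yl group, so neither the need for both fluorine atoms nor the cost of the amine can yet be judged.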